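The compounds below may be only part of what the source reports. "The series", "measured", "known", "first", "only" and "open" are said of these compounds alone.

Measured compounds:

Compound 1, `O=S(=O)(Nc1ccc(F)c(C#Cc2cnc3[nH]ncc3c2)c1F)c1ccccn1`, gives in a functional assay on HCT-116 cells (Homo sapiens) for antiproliferative activity, read by MTT assay, with a stated time of 68 h (on this read-out higher numbers stand for weaker inhibition and lower numbers for stronger inhibition), the value > 10000 nM, which is a limit of the assay rather than a number.

Compound 2, `CCOc1n[nH]c2ncc(C#Cc3c(F)ccc(NS(=O)(=O)c4cccnc4)c3F)cc12`, gives in this assay the value 10000 nM.

Within the data shown here, compound 2 therefore holds the only actual number in this assay; the single further value shown, that of compound 1, is a limit. Among the measured compounds shown here, the two values together show only that both compounds are weak inhibitors, and nothing beyond that can be read from them, since the limit of > 10000 nM in this assay, at which 1 of the 2 values shown sits, describes where the value of compound 1 sits.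

Compound 3, `O=S(=O)(Nc1ccc(F)c(C#Cc2cnc3[nH]nc(-c4ccc(F)cc4)c3c2)c1F)c1cccnc1`, is not yet measured. It differs from compound 2 by 4-fluorophenyl in place of ethoxy on an aromatic carbon.

For the measured compounds named here, no measured step of this kind is available, so the size and direction of the change in this assay is open. An aryl ring of this size is a substantial alteration, and an author estimating compound 3 would expect a modest improvement, with a wide range. Compound 3 is estimated at 3000 nM, between 300 nM and 12000 nM. That estimate corresponds to an expected step of a 3.3-fold lower number from compound 2 to compound 3 (0.52 log units; beyond the scatter).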

Compound 3, half-maximal inhibitory concentration: > 10000 nM
Compound 3: no number, only a limit; the forecaster's own chance of this, stated with the estimate: 30%; middle value at least 3.3-fold (0.52 log units) away from the limit.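

In this assay compound 3 gives > 10000 nM, which is a limit of the assay and not a number. Among these compounds, the exchange of ethoxy for 4-fluorophenyl on this aromatic carbon of the five-membered ring therefore gives a number no lower from compound 2 to compound 3 (the limit leaves the size open), so the larger aromatic group brings no gain in antiproliferative activity here, which the earlier compounds could not show because none of them formed a single-place step at this position. The values now gather at one end of the read-out: the limit of > 10000 nM in this assay, at which 2 of the 3 values shown sit.

How far compound 3 lies from compound 2 cannot be read, so the compounds shown do not say whether this change leaves the value about where it was or weakens it further. They also leave open whether an amine, a methoxy group or a longer alkoxy chain on this same carbon would give a value that can be read as a number.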